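Swapping 4-(methoxymethyl)phenyl for 2-methylphenyl on the shared core

The source may report more compounds than this note shows. Statements on the series, on what has been measured and on what is new or still open speak of the compounds shown alone.

In a functional assay on KB cells (Homo sapiens) for antiproliferative activity, read by sulforhodamine B assay, with a stated time of 3 days (on this read-out lower numbers stand for an effect already at smaller amounts and higher numbers for an effect only at larger amounts of compound), compound 1 `CCC1=C(O)c2c(oc(-c3ccc(CC)cc3)cc2=O)C(CC)(CC)C1=O` gives 21.9 uM. Compound 2 `CCC1=C(O)c2c(oc(-c3ccc(COC)cc3)cc2=O)C(CC)(CC)C1=O` stands only at a limit, > 52.4 uM, and has no exact number. Compound 3 `CCC1=C(O)c2c(oc(-c3ccccc3C)cc2=O)C(CC)(CC)C1=O` carries 2-methylphenyl in place of 4-(methoxymethyl)phenyl on an aromatic carbon, next to the ring oxygen (2-methylphenyl in place of 4-(methoxymethyl)phenyl on an aromatic carbon). For the measured compounds named here, only one measured step bears on this change: an at least 2.3-fold higher number from compound 1 to compound 2 (0.37 log units; beyond the scatter). That step lies beyond the scatter and is at least modest. It brings in the methoxy that compound 3 does not have, but the aryl group of compound 3 also differs from that of compound 1, so the guidance is only partial. A modest move towards a lower number in this assay is therefore expected, and its size remains uncertain. The expected change is an at least 1.7-fold lower number from compound 2 to compound 3 (0.24 log units; that floor lies within the scatter). The estimate for compound 3 is 30 uM, with an expected range of 13 uM to 70 uM.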

Compound 3, concentration for half-maximal effect: 40.9 uM
The estimate for compound 3 lay 1.4-fold (0.13 log units) below the measured number, within the range that was stated.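

In this assay, the exchange of 4-ethylphenyl for 2-methylphenyl on the aromatic carbon next to the ring oxygen gives a 1.9-fold higher number from compound 1 to compound 3 (0.27 log units; within the scatter), so these two aryl groups are not told apart at this position. The exchange of 4-(methoxymethyl)phenyl for 2-methylphenyl gives an at least 1.2-fold lower number from compound 2 to compound 3 (0.10 log units; that floor lies within the scatter), and that floor fixes no size for the change. Compound 2 is known only at a limit and not as a number: the limit of > 52.4 uM in this assay, at which 1 of the 3 values shown sits.

The compounds shown leave open how far the true number of compound 2 lies from its limit, and with it the real size of this change. They also leave open what a phenyl ring carrying an amine, a carboxylic acid or a longer chain in place of the methyl of 2-methylphenyl would give at this position.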